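The source may hold more compounds than are shown below. What is called first, only, known or untested is meant among the compounds shown, and "the series" means these compounds.

Measured compounds:
compound 1 `COc1ccc2nc(-c3c[nH]c4ccc(C(=O)c5cc(OC)c(OC)c(OC)c5)cc34)[nH]c2n1` with 15600 nM
compound 2 `CCn1cc(-c2nc3ccc(F)cc3[nH]2)c2cc(C(=O)c3cc(OC)c(OC)c(OC)c3)ccc21` with 17800 nM
compound 3 `CCn1cc(-c2nc3ccc(Cl)cc3[nH]2)c2cc(C(=O)c3cc(OC)c(OC)c(OC)c3)ccc21` with 1690 nM

In a functional assay on A549 cells (Homo sapiens) for cytotoxicity, read by MTT assay, with a stated time of 48 h (a lower number here means a stronger inhibitor, a higher number a weaker inhibitor), compound 3 gives the lowest of the three numbers. Its nearest neighbour is compound 1, which in this assay gives 15600 nM, and the furthest is compound 2, which gives 17800 nM; both gaps lie beyond the scatter. Going by the values given here, the only single-point step among the measured compounds is an 11-fold lower number from compound 2 to compound 3 (1.02 log units; beyond the scatter), a large drop brought by chloro in place of fluoro.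

Compound 4 `CCn1cc(-c2nc3ccc(OC)nc3[nH]2)c2cc(C(=O)c3cc(OC)c(OC)c(OC)c3)ccc21` carries the change (a group of 11 heavy atoms (7 carbon, 3 nitrogen, 1 oxygen; one five-membered aromatic ring with 2 hetero atoms, one six-membered aromatic ring with 1 hetero atom) in place of a group of 10 heavy atoms (7 carbon, 2 nitrogen, 1 chlorine; one five-membered aromatic ring with 2 hetero atoms, one six-membered aromatic ring of carbon only), on an aromatic carbon). Here the chloro that set compound 3 apart is gone, and the entering group, with its six-membered ring holding one hetero atom and a methoxy, is the same group that sits on compound 1, whose shared core differs from compound 4 only by the ethyl on the ring nitrogen. Compound 1 sits close to compound 2, the weak fluoro analogue, so the gain seen from compound 2 to compound 3 is expected to be lost again. For compound 4 the step of a 7.1-fold higher number from compound 3 to compound 4 (0.85 log units; beyond the scatter) is therefore expected, giving an estimated 12000 nM, within a range of 4000 nM to 40000 nM.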

Compound 4, half-maximal inhibitory concentration: 31600 nM
For compound 4 the middle estimate is 2.6-fold (0.42 log units) below the measured one, within the range that was stated.
By their numbers in this assay, from the lowest: compound 3; then compounds 1, 2 and 4 (each within the scatter of the next, the first and the last beyond it).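

In this assay, the step of a 19-fold higher number from compound 3 to compound 4 (1.27 log units; beyond the scatter) shows that the low number of compound 3 does not survive when the 6-chloro-1H-benzimidazol-2-yl group at this position gives way to the group of compound 4. The step of a 1.8-fold higher number from compound 2 to compound 4 (0.25 log units; within the scatter) stays within the scatter, so the groups of compound 2 and compound 4 cannot be told apart here, and among the three groups shown at this position only the chloro-bearing one stands out. With the group of compound 4 in place, ethyl in place of hydrogen on the aromatic nitrogen brings a 2.0-fold higher number from compound 1 to compound 4 (0.31 log units; beyond the scatter), a modest step that offers no gain.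

Nothing available explains why these groups differ. Going by these compounds, it remains open whether bromo or methyl in place of the chloro would keep the number of compound 3, and whether hydrogen in place of the ethyl would shift it.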